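The source may report more compounds than this note shows. Statements on the series, on what has been measured and on what is new or still open speak of the compounds shown alone.

Measured so far:
Compound 1, `CCC(CC)C(=O)Nc1c(C(O)(C(F)(F)F)C(F)(F)F)ccc2ccccc12`: 4340 nM
Compound 2, `CC(C)=CC(=O)Nc1c(C(O)(C(F)(F)F)C(F)(F)F)ccc2ccccc12`: 46 nM
Compound 3, `O=C(CC1CCCC1)Nc1c(C(O)(C(F)(F)F)C(F)(F)F)ccc2ccccc12`: 81 nM

In an assay on LtK cells with ATP-sensitive inward rectifier potassium channel 11 (Homo sapiens) as the target (a higher number here means that more compound is needed for the effect, a lower number that less compound is needed), compound 3 stands second of the three numbers; its nearest neighbour is compound 2, and the gap between them, a 1.8-fold higher number from compound 2 to compound 3 (0.25 log units; within the scatter), is within the scatter, so the two cannot be told apart. Compound 1 lies much further off, a 54-fold lower number from compound 1 to compound 3 (1.73 log units; beyond the scatter).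

Compound 4, `O=C(Nc1c(C(O)(C(F)(F)F)C(F)(F)F)ccc2ccccc12)c1cccc(Cl)c1`, differs from compound 3 at one place: 3-chlorophenyl in place of cyclopentylmethyl on a carbonyl carbon.

Two measured steps change the same group on the carbonyl carbon. a 94-fold lower number from compound 1 to compound 2 (1.97 log units; beyond the scatter) and a 54-fold lower number from compound 1 to compound 3 (1.73 log units; beyond the scatter) both show that replacing pentan-3-yl gives a much lower number, while a 1.8-fold higher number from compound 2 to compound 3 (0.25 log units; within the scatter) shows two of the replacements to be alike within the scatter. Going by the values given here, no measured compound carries an aromatic ring or a chlorine at this place, so the effect of 3-chlorophenyl is not tested. The expectation for compound 4 is therefore a step of about a 1.5-fold higher number from compound 3 to compound 4 (0.17 log units; within the scatter), with wide uncertainty. Compound 4 is estimated at 120 nM in this assay, between 25 nM and 600 nM.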

Compound 4, half-maximal effective concentration: 98 nM
Beside the measured number, compound 4's estimate is 1.2-fold (0.09 log units) above it, within the range that was stated.
By their numbers in this assay, from the lowest: compounds 2, 3 and 4 (each within the scatter of the next, the first and the last beyond it); then compound 1.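

In this assay, the place on the carbonyl carbon also takes an aromatic ring: 3-chlorophenyl cannot be told apart from cyclopentylmethyl (a 1.2-fold higher number from compound 3 to compound 4 (0.08 log units; within the scatter)), so a non-aromatic ring is not needed here. Going by these compounds alone, two further steps place the new group among the others: a 2.1-fold higher number from compound 2 to compound 4 (0.33 log units; beyond the scatter) is modest and just beyond the scatter, while a 44-fold lower number from compound 1 to compound 4 (1.65 log units; beyond the scatter) is large, leaving pentan-3-yl as the one group of the four that stands well apart. No measurement available here explains why these groups give these numbers.

The compounds shown leave open whether the chlorine matters, since a plain phenyl, or a phenyl ring carrying an amine or a carboxylic acid, is not among them. Also open, from the compounds shown here alone, is how a cyclopentyl ring joined directly to the carbonyl carbon, or a longer chain, would compare with pentan-3-yl.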